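Removing the methyl from compound 3

This account rests on a few compounds, and the source may have more. Where it says the series, first, only, none or still open, it means among the compounds named here.

Compound 3 `Cc1ccc(-n2c(Nc3nc(-c4ccc(Br)cc4)cs3)n[nH]c2=S)cc1` is one of three analogues on a shared core tested in a functional assay on the whole organism (strain Swiss albino) for inhibition, with Mus musculus as the target, with a stated time of 4 h; a lower number here means that less compound is needed, a higher number that more compound is needed for the effect. In that assay compound 3 gives 300 mg/kg. Compound 1 `COc1ccccc1-n1c(Nc2nc(-c3ccc(Br)cc3)cs2)n[nH]c1=S` gives 300 mg/kg, and compound 2 `S=c1[nH]nc(Nc2nc(-c3ccc(Cl)cc3)cs2)n1-c1ccccc1` gives 300 mg/kg, so compound 3 stands level with both. Within the data shown here, the one step measured among them, no change at the digits printed from compound 1 to compound 3 (within the scatter), lies within the scatter. Compound 4 `S=c1[nH]nc(Nc2nc(-c3ccc(Br)cc3)cs2)n1-c1ccccc1` is yet to be measured; it differs from compound 3 by hydrogen in place of methyl on an aromatic carbon. Compound 2, which carries the same phenyl on the aromatic nitrogen, gives a value within the scatter of that of compound 3. Because no change at the digits printed from compound 1 to compound 3 (within the scatter) lay within the scatter, no step beyond the scatter is expected here either: no change at the digits printed from compound 3 to compound 4 (within the scatter). Compound 4 is therefore estimated at 300 mg/kg, between 150 mg/kg and 600 mg/kg.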

Compound 4, minimum effective dose: 300 mg/kg
Estimate against measurement, compound 4: no gap at the digits printed; the range from low to high includes it.
By their numbers in this assay, from the lowest: compounds 1, 2, 3 and 4 (each within the scatter of the next).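

In this assay, going from 4-methylphenyl to phenyl gives no change at the digits printed from compound 3 to compound 4 (within the scatter), so methyl and hydrogen read alike at this position, para to a large group. Hydrogen in place of methoxy gives no change at the digits printed from compound 1 to compound 4 (within the scatter), and bromo in place of chloro, the first measured step at the halogen, gives no change at the digits printed from compound 2 to compound 4 (within the scatter). No supporting measurement bears on this result.

With all four compounds level, the series leaves open whether an amine, a carboxylic acid or a longer chain at this position would shift the minimum effective dose.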